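Acid-to-amide switch on the shared core: lipophilicity note

The source may hold more compounds than are shown below. What is called first, only, known or untested is meant among the compounds shown, and "the series" means these compounds.

Of the compounds shown here, three have been read in a physicochemical assay for lipophilicity, read by HPLC, at pH 7.5; a higher number here means a more lipophilic compound, a lower number a more polar compound. Compound 1 `CCOc1ccccc1-c1ccc(-c2nc3cnccc3c(NC(C)C(=O)O)c2C#N)cc1` gives 2.1. Compound 2 `N#Cc1c(-c2ccc(Br)cc2)nc2cnccc2c1NCC(N)=O` gives 1.9, a value that lies within the usual scatter of that of compound 1, so the two cannot be ranked against each other. Compound 3 `CC[C@@H](Nc1c(C#N)c(-c2ccc(-c3ccccc3C)cc2)nc2cnccc12)C(N)=O` gives 3, which lies beyond the scatter above compound 1; on the three numbers shown, compound 1 therefore stands with compound 2 and below compound 3 only.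

Compound 4 `CCOc1ccccc1-c1ccc(-c2nc3cnccc3c(NC(C(N)=O)C3CC3)c2C#N)cc1` has not yet been measured in this assay. It differs from compound 1 in one place: a group of 7 heavy atoms (5 carbon, 1 nitrogen, 1 oxygen; one three-membered non-aromatic ring of carbon only) in place of a group of 5 heavy atoms (3 carbon, 2 oxygen; no ring), on a nitrogen on an aromatic ring

Among the compounds with values here, no step between measured compounds matches this change, so the size of the expected step rests on the wider set. Compound 3, which also carries a primary amide on the nitrogen of the core and a biphenyl with a single substituent, gives 3, and on that basis a step upward beyond the scatter is expected, namely a number 0.90 log units higher from compound 1 to compound 4 (beyond the scatter). For compound 4 the expected value in this assay is 3, with a range from 2.4 to 3.6.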

Compound 4, distribution coefficient: 3
Compound 4: middle estimate and measured number agree at the digits printed; the range from low to high includes it.
By their numbers in this assay, from the lowest: compounds 2 and 1 (each within the scatter of the next); then compounds 3 and 4 (each within the scatter of the next).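

In this assay, within the data shown here, replacing the 1-carboxyethyl group on the nitrogen on an aromatic ring with the group carrying the three-membered carbon ring gives a number 0.90 log units higher from compound 1 to compound 4 (beyond the scatter), the only step that can be read at this position. Among these compounds, the two groups have the same counted hydrogen-bond donors and acceptors but differ in heavy atoms and ring, and the single step cannot be divided between the amide and the ring. No available evidence bears on the origin of this step.

Open, going by these compounds, is how much of the step follows the exchange of the carboxylic acid for the primary amide, and how much follows the three-membered ring. A primary amide with a plain methyl group, or an isopropyl group in place of the ring, would separate the two contributions on the core of compound 1.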